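From 2,6-difluorobenzyl to 2,5-difluorobenzyl

This account rests on a few compounds, and the source may have more. Where it says the series, first, only, none or still open, it means among the compounds named here.

Measured in a functional assay on Bel-7402 cells (Homo sapiens) for antiproliferative activity, read by MTT assay, with a stated time of 72 h; a lower number here means a stronger inhibitor, a higher number a weaker inhibitor:
Compound 1 `C=C1C(=O)O[C@H]2[C@H]1CC/C(COC(=O)Cn1cc(F)c(=O)[nH]c1=O)=C\CC[C@@]1(C)O[C@@H]21`: > 20000 nM, which is a limit and not a number
Compound 2 `C=C1C(=O)O[C@H]2[C@H]1CC/C(COC(=O)Cn1cc(F)c(=O)n(Cc3ccccc3)c1=O)=C\CC[C@@]1(C)O[C@@H]21`: 3980 nM
Compound 3 `C=C1C(=O)O[C@H]2[C@H]1CC/C(COC(=O)Cn1cc(F)c(=O)n(Cc3c(F)cccc3F)c1=O)=C\CC[C@@]1(C)O[C@@H]21`: 4500 nM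

In this assay compound 3 gives 4500 nM. That places it level with compound 2 once the scatter is allowed for, the measured step being a 1.1-fold higher number from compound 2 to compound 3 (0.05 log units; within the scatter).

Compound 4 `C=C1C(=O)O[C@H]2[C@H]1CC/C(COC(=O)Cn1cc(F)c(=O)n(Cc3cc(F)ccc3F)c1=O)=C\CC[C@@]1(C)O[C@@H]21` keeps the core of compound 3 and changes only the fluorine pattern of the benzyl group: 2,5-difluorophenyl in place of 2,6-difluorophenyl on a saturated chain carbon bound to an aromatic nitrogen. The two have the same atoms, joined differently.

Two measured steps show that a group on the aromatic nitrogen goes with a lower number: an at least 5.0-fold lower number from compound 1 to compound 2 (0.70 log units; beyond the scatter) and an at least 4.4-fold lower number from compound 1 to compound 3 (0.64 log units; beyond the scatter). Compound 4 keeps such a group, so these steps give no reason to expect a large shift. The step that bears most closely on the change is a 1.1-fold higher number from compound 2 to compound 3 (0.05 log units; within the scatter), where 2,6-difluorophenyl took the place of phenyl at the same site. Among the measured compounds shown here, no measured compound carries the 2,5-difluorophenyl group, so the expectation rests on that small step alone.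

The expected change is a 1.1-fold lower number from compound 3 to compound 4 (0.03 log units; within the scatter), with no step beyond the scatter foreseen in either direction. For compound 4 the estimated value is 4200 nM, with an expected range from 2000 nM to 9000 nM.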

Compound 4, half-maximal inhibitory concentration: 3060 nM
For compound 4 the middle estimate is 1.4-fold (0.14 log units) above the measured one, and the stated range covers the measured number.
By their numbers in this assay, from the lowest: compounds 4, 2 and 3 (each within the scatter of the next). At a limit, above all of these: compound 1.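

Moving one fluorine, so that 2,5-difluorophenyl replaces 2,6-difluorophenyl on a saturated chain carbon bound to an aromatic nitrogen, leaves the result level in this assay: a 1.5-fold lower number from compound 3 to compound 4 (0.17 log units; within the scatter), and the comparison with plain phenyl gives a 1.3-fold lower number from compound 2 to compound 4 (0.11 log units; within the scatter). Compounds 2, 3 and 4 therefore show no separation at this site between an unfluorinated ring and either fluorine pattern shown, while a third compound now supports the contrast with the hydrogen on the aromatic nitrogen: an at least 6.5-fold lower number from compound 1 to compound 4 (0.81 log units; beyond the scatter). Compound 1 stands at a limit and not a number, so that step gives only a bound: the limit of > 20000 nM in this assay, at which 1 of the 4 values shown sits.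

Every substituted compound shown carries a benzyl group with hydrogen or fluorine on its ring, so it remains open whether chlorine, methoxy or a nitrile on that ring, or a longer chain between the ring and the aromatic nitrogen, would move the number beyond the scatter. Also open, as far as these compounds go, is how a group without an aromatic ring, such as a plain alkyl chain or a chain ending in an amine, would compare with the benzyl groups at this site.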